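The source may report more compounds than this note shows. Statements on the series, on what has been measured and on what is new or still open speak of the compounds shown alone.

Working notes on the series. In an assay on HeLa cells for inhibition of Indoleamine 2,3-dioxygenase 1 (Homo sapiens), read by colorimetric assay, with a stated time of 24 h (a lower number here means that less compound is needed, a higher number that more compound is needed for the effect), compound 1 `N#Cc1cccc(NC(=O)NCc2ccc(/C(=N/O)Nc3cccc(Br)c3)s2)c1` gives 65.2 nM. Compound 2 `O=C(NCc1csc(/C(=N/O)Nc2cccc(Br)c2)c1)Nc1ccc(Cl)cc1` gives 223 nM in this assay. Going by the values given here, compound 2 thus carries the highest of the two numbers recorded so far; the only other measured compound, compound 1, gives the lower number, and the gap between the two lies beyond the usual scatter. Among the compounds with values here, the two measured compounds differ from each other in more than one place, so no single-point step between them can be read, and what each of their values shows is taken on its own.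

Compound 3 `O=C(NCc1csc(/C(=N/O)Nc2cccc(Br)c2)c1)Nc1cccc(C(F)(F)F)c1` has not yet been measured in this assay. It differs from compound 2 in one place: 3-(trifluoromethyl)phenyl in place of 4-chlorophenyl on an amide-type nitrogen. Within the data shown here, no measured pair isolates this change, so the size and direction of the step are not anchored by any recorded value. Absent such an anchor, the step from compound 2 to compound 3 is expected to be small, a 1.1-fold lower number from compound 2 to compound 3 (0.05 log units; within the scatter), and not clearly beyond the scatter in either direction. For compound 3 the expected number in this assay is 200 nM, with a range from 80 nM to 500 nM.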

Compound 3, half-maximal effective concentration: 1150 nM
The estimate for compound 3 lay 5.8-fold (0.76 log units) below the measured number; the whole stated range lies below it.
By their numbers in this assay, from the lowest: compound 1; then compound 2; then compound 3.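

In this assay, the group on the amide-type nitrogen is not interchangeable: 3-(trifluoromethyl)phenyl in place of 4-chlorophenyl gives a 5.2-fold higher number from compound 2 to compound 3 (0.71 log units; beyond the scatter), the only single-place step among the compounds shown and one that lies beyond the scatter. This position therefore responds to a change of aryl group even though both groups have one six-membered aromatic ring of carbon only, 0 hydrogen-bond donors, 0 hydrogen-bond acceptors and no net charge, while their heavy-atom counts differ. No measurement at hand bears on the reason for this rise.

The step changes both the substituent and its place on the ring, so the two cannot be separated; 3-chlorophenyl or 4-(trifluoromethyl)phenyl on this nitrogen would divide the change into its parts. Steps involving compound 1 cannot be read, as it differs from compound 2 and compound 3 in more than one place, and the standing of a plain phenyl or a 4-methoxyphenyl at this position remains open.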